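The source may report more compounds than this note shows. Statements on the series, on what has been measured and on what is new or still open speak of the compounds shown alone.

Compound 1, `CCOC(=O)[C@@H](NC(=O)[C@H](NC(=O)CCCC(=O)O)[C@@H](O)CO)[C@@H](C)O[C@@H]1O[C@@H](C)[C@@H](O)C(O)C1O`: in an assay on isolated protein for inhibition of E-selectin (Homo sapiens) (a lower number here means a stronger inhibitor, a higher number a weaker inhibitor), compound 1 gives 500000 nM.
Compound 2, `CCOC(=O)[C@@H](NC(=O)C(CO)(CO)NC(=O)CCCC(=O)O)[C@@H](C)O[C@@H]1O[C@@H](C)[C@@H](O)C(O)C1O`: in this assay compound 2 gives 900000 nM.
Compound 3, `CCOC(=O)[C@@H](NC(=O)[C@@H]1C[C@H](O)CN1C(=O)CCCC(=O)O)[C@@H](C)O[C@@H]1O[C@@H](C)[C@@H](O)C(O)C1O`: in this assay compound 3 gives 1000000 nM.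

The three numbers lie close together. The value of compound 3 sits within the usual scatter of the value of compound 2 and also of the value of compound 1, so none of the three can be set apart from the others on these data; all of them are weak inhibitors.

Compound 4, `CCOC(=O)[C@@H](NC(=O)[C@H]1C[C@@H](O)CN1C(=O)CCCC(=O)O)[C@@H](C)O[C@@H]1O[C@@H](C)[C@@H](O)C(O)C1O`, has not yet been measured. It differs from compound 3 in this way: the two compounds have the same atoms and bonds; at least one stereo element is drawn with a configuration in one of them and without one in the other: 2 of 9 stereo elements differ; a stereocentre at a saturated ring carbon is drawn S in compound 3 and R in compound 4; a stereocentre at a saturated ring carbon is drawn S in compound 3 and R in compound 4. Within the data shown here, no step between measured compounds is available that would show how such a change alone moves the number, and the three measured compounds offer no pattern on which a direction could rest. Compound 3 is the only point of reference. Compound 4 is expected to show a step of no change at the digits printed from compound 3 to compound 4 (within the scatter) that stays within the scatter, in no particular direction. Compound 4 is therefore estimated at 1000000 nM in this assay, with a range from 300000 nM to 3000000 nM.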

Compound 4, half-maximal inhibitory concentration: 3000000 nM
Compound 4: the middle estimate sits 3.0-fold (0.48 log units) below what was measured; the range from low to high includes it.
By their numbers in this assay, from the lowest: compounds 1, 2 and 3 (each within the scatter of the next); then compound 4.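

In this assay, the drawn configuration of the two stereocentres at saturated ring carbons makes a readable difference on its own, since inverting them with no atom or bond changed gives a 3.0-fold higher number from compound 3 to compound 4 (0.48 log units; beyond the scatter). Among these compounds, this is the first step that isolates a single kind of change, and it shows that this part of the molecule is sensitive to stereochemistry even among such weak inhibitors. The step needs one caution in its reading: the fact that one of compounds 3 and 4 is drawn with a defined configuration and the other without, at the place where they differ

Both stereocentres change together, so the compounds shown do not tell whether one of them accounts for the step or both contribute. They also leave open how the number would respond if an amine took the place of the ring hydroxyl, in either configuration.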